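This account rests on a few compounds, and the source may have more. Where it says the series, first, only, none or still open, it means among the compounds named here.

Measured compounds:
- compound 1 `COCCN(C)S(=O)(=O)c1ccc(C)c(C#Cc2cc(Cl)ccc2OCC(=O)O)c1`; in an ADME assay on a cell-free system (plasma, Rattus norvegicus) (a lower number here means a smaller unbound share, a higher number a larger unbound share of the compound), compound 1 gives 0.007
- compound 2 `Cc1ccc(S(=O)(=O)N(C)C(C)C)cc1C#Cc1cc(Cl)ccc1OCC(=O)O`; compound 2 gives "not determined" (no result reported)
- compound 3 `COCCNS(=O)(=O)c1ccc(C)c(C#Cc2cc(Cl)ccc2OCC(=O)O)c1`; compound 3 gives "not determined" (no result reported)

Working notes on the series. Only compound 1 carries a number in this assay, and that number sits at the low end of the scale, a small unbound share. Within the data shown here, compound 3 has no number there: its entry, like that of compound 2, is without a result, so it stands nowhere on the scale yet, and no step from compound 3 to any other compound can be read off.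

The step to the unmeasured compound 4 `Cc1ccc(S(=O)(=O)NC(C)C)cc1C#Cc1cc(Cl)ccc1OCC(=O)O` is a single change: isopropyl in place of 2-methoxyethyl on a sulfonamide nitrogen. Both compounds keep the shared core with its carboxylic acid and the sulfonamide, and only the group on the sulfonamide nitrogen is exchanged.

Among the measured compounds shown here, no step between measured compounds is available to size this change. Within the series the one known value, that of compound 1 in this assay, is small, and compound 3 itself gives nothing to anchor a direction. The expectation is therefore a step of no more than the usual scatter in either direction, with the unbound share staying small.

Compound 4 is expected in this assay at 0.01, within 0.003 to 0.03.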

Compound 4, unbound fraction: 0.004
The estimate for compound 4 lay 2.5-fold (0.40 log units) above the measured number; low and high end bracket the measured number.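

In this assay the series now has its first readable step at the sulfonamide nitrogen, a 1.8-fold lower number from compound 1 to compound 4 (0.24 log units; within the scatter), with isopropylamino in place of (2-methoxyethyl)(methyl)amino on a sulfonyl sulfur. This change replaces the whole substitution on that nitrogen, yet the step stays within the scatter, and the unbound share remains small both for compound 1 at 0.007 and for compound 4 at 0.004 in this one comparison, while steps to compound 2 and compound 3 cannot be read, as neither has a number. No measurement shown bears on a cause for this result.

Among these compounds, the single step joins two groups that differ in more than one respect, so the separate contributions of the methyl group and of the exchange of 2-methoxyethyl for isopropyl remain unresolved in this assay. Also open, going by these compounds, is whether an amine or a carboxylic acid at the end of a longer chain on the sulfonamide nitrogen would move the unbound share beyond the small values seen so far, since every compound with a number here carries only neutral groups at this place.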